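Nitro in place of methylsulfonyl: cytotoxicity working notes

The compounds below may be only part of what the source reports. "The series", "measured", "known", "first", "only" and "open" are said of these compounds alone.

Compound 1 `CC(C)N(Cc1cccc(OCCCCCC(=O)O)c1)C(=O)c1ccc(-c2ccsc2)cc1` serves as the first point in an ADME assay on HEK293 cells (Homo sapiens) for cytotoxicity, read by CellTiter-Glo and resazurin assay, with a stated time of 72 h; a lower number here means that less compound is needed, a higher number that more compound is needed for the effect. In this assay compound 1 reaches only the limit > 26000 nM, which is a limit of the assay and not a number. Compound 2 `CC(C)N(Cc1cccc(OCCCCCC(=O)O)c1)C(=O)c1ccc(-c2cccc(S(C)(=O)=O)c2)cc1` also gives in this assay only the limit > 26000 nM. The step that the two limits leave unreadable from compound 1 to compound 2 therefore cannot be read because both values sit at the limit of > 26000 nM in this assay, at which 2 of the 2 values shown sit. Compound 3 `CC(C)N(Cc1cccc(OCCCCCC(=O)O)c1)C(=O)c1ccc(-c2cccc([N+](=O)[O-])c2)cc1` differs from compound 2 by nitro in place of methylsulfonyl on an aromatic carbon. No readable measured step bears on this change. Compound 3 is therefore expected to sit again at the limit, estimated at 40000 nM with a range from 20000 nM to 100000 nM. The expected step is a step that the limit leaves unreadable from compound 2 to compound 3, not readable beyond the scatter.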

Compound 3, half-maximal effective concentration: > 26000 nM
Compound 3: a limit, no number; the forecaster's own chance of this, stated with the estimate: 85%; the middle value lies beyond the limit too.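

No step among compound 1, compound 2 and compound 3 can be read in this assay, because all three give a limit and not a number: the limit of > 26000 nM in this assay, at which 3 of the 3 values shown sit.

In this assay the compounds shown leave open which change on this aromatic carbon, if any, would give a readable number.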